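The source may report more compounds than this note shows. Statements on the series, on what has been measured and on what is new or still open speak of the compounds shown alone.

Series notes. Going by the values given here, compound 1 `c1ccc(-c2nc(-c3c[nH]c4ccccc34)co2)cc1` gives 131000 nM in a functional assay on MCF7 cells (Homo sapiens) for cytotoxicity, read by MTT assay, with a stated time of 48 h (on this read-out higher numbers stand for weaker inhibition and lower numbers for stronger inhibition), the highest of the two numbers measured so far; its nearest neighbour is compound 2 `Fc1ccc(-c2nc(-c3c[nH]c4ccccc34)co2)cc1`, which in this assay gives 28000 nM. Among the compounds with values here, the single measured step, a 4.7-fold lower number from compound 1 to compound 2 (0.67 log units; beyond the scatter), is a modest change beyond the scatter and the only one available for comparison.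

Compound 3 `Clc1ccc(-c2nc(-c3c[nH]c4ccccc34)co2)cc1` differs from compound 1 by chloro in place of hydrogen on an aromatic carbon, the chloro counterpart of the fluoro change already measured. Within the data shown here, no chloro-for-hydrogen step has been measured in this set, so the expectation rests solely on the fluoro step, a 4.7-fold lower number from compound 1 to compound 2 (0.67 log units; beyond the scatter), which was beyond the scatter. A step of comparable size in the same direction is expected, and the estimated change is a 5.2-fold lower number from compound 1 to compound 3 (0.72 log units; beyond the scatter). Compound 3 is accordingly estimated at 25000 nM in this assay, with a plausible range from 8000 nM to 80000 nM.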

Compound 3, half-maximal inhibitory concentration: 410000 nM
The estimate for compound 3 lay 16-fold (1.21 log units) below the measured number; measured number outside the range, above it.
By their numbers in this assay, from the lowest: compound 2; then compound 1; then compound 3.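

At this position, on the six-membered aromatic ring and para to a large group, the two halogen changes do not share a direction in this assay: with chloro, the result is a 3.1-fold higher number from compound 1 to compound 3 (0.50 log units; beyond the scatter), opposite to the fluoro change, which gave a 4.7-fold lower number from compound 1 to compound 2 (0.67 log units; beyond the scatter). Exchanging one halogen for the other at the same carbon gives a 15-fold higher number from compound 2 to compound 3 (1.17 log units; beyond the scatter), so the fluoro step alone is no guide to the chloro compound here. Nothing available on these compounds accounts for the reversal.

Open, as far as these compounds go, is whether a bromo group, a methyl group or an amine at this carbon would fall nearer compound 2 or compound 3. Also open, from the compounds shown here alone, is whether chloro would raise the number similarly at another carbon of the same ring.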